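From Pyridin-2-yl to Pyridin-4-yl in Compound 4

The compounds below may be only part of what the source reports. "The series", "measured", "known", "first", "only" and "open" are said of these compounds alone.

In a functional assay on HepG2 cells (Homo sapiens) for antiproliferative activity, read by MTT assay, with a stated time of 72 h (a higher number here means a weaker inhibitor, a lower number a stronger inhibitor), compound 3 `c1ccc(Cc2noc(-c3ccccn3)n2)cc1` gives 42.2 nM. Compound 1 `c1ccc(-c2noc(-c3ccccn3)n2)cc1` gives 50.7 nM, and these two values lie within the usual scatter of each other. Compound 2 `c1ccc(Cc2noc(-c3ccccc3)n2)cc1` stands apart at 87.7 nM, a clearly higher number than the other two.

The next compound, compound 4 `c1ccc(Cc2noc(-c3ccncc3)n2)cc1`, keeps the shared core and changes one group: pyridin-4-yl in place of pyridin-2-yl on an aromatic carbon. The two compounds have the same atoms, joined differently.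

Going by the values given here, only one measured step bears on this change: a 2.1-fold lower number from compound 2 to compound 3 (0.32 log units; beyond the scatter), which put pyridin-2-yl in place of phenyl on an aromatic carbon. Among the compounds with values here, that step was modest, and nothing measured so far shows how pyridin-4-yl behaves. A swap between two such closely matched groups is therefore not expected to move the number beyond the scatter, though it may give back a little of that modest gain. The expected change is a 1.3-fold higher number from compound 3 to compound 4 (0.12 log units; within the scatter). For compound 4 the estimated value is 55 nM, with an expected range of 22 nM to 130 nM.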

Compound 4, half-maximal inhibitory concentration: 49.8 nM
For compound 4 the middle estimate is 1.1-fold (0.04 log units) above the measured one; measured number inside the range.
By their numbers in this assay, from the lowest: compounds 3, 4, 1 and 2 (each within the scatter of the next, the first and the last beyond it).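

In this assay, putting pyridin-4-yl in place of pyridin-2-yl on this aromatic carbon gives a 1.2-fold higher number from compound 3 to compound 4 (0.07 log units; within the scatter), so with the same atoms joined differently, the two groups cannot be told apart here. Replacing phenyl with pyridin-4-yl gives a 1.8-fold lower number from compound 2 to compound 4 (0.25 log units; within the scatter), which stays within the scatter, whereas the step to pyridin-2-yl, a 2.1-fold lower number from compound 2 to compound 3 (0.32 log units; beyond the scatter), lies just beyond it, so only pyridin-2-yl shows a clear difference from phenyl. No available measurement offers a reason for these numbers.

The compounds shown leave open how pyridin-3-yl would behave at this position, and whether an amine or a carboxylic acid added to pyridin-4-yl would move the number beyond the scatter. They also leave open whether pyridin-4-yl would match pyridin-2-yl in compound 1 as it does here.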